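From phenyl to 3,5-dimethoxyphenyl in the amide series

The source may hold more compounds than are shown below. What is called first, only, known or untested is meant among the compounds shown, and "the series" means these compounds.

In a functional assay on HCT-116 cells (Homo sapiens) for antiproliferative activity, read by MTT assay, with a stated time of 72 h (on this read-out lower numbers stand for stronger inhibition and higher numbers for weaker inhibition), compound 1 (`CC(C)c1cccc(NC(=O)CCc2cccc3c2B(O)OC3)c1`) gives 1600 nM and compound 2 (`O=C(CCc1cccc2c1B(O)OC2)Nc1cccc(-c2ccccc2)c1`) gives 890 nM. Going by the values given here, these two numbers lie within the scatter of each other, so compound 2 stands level with its only measured neighbour. Compound 3 (`COc1cc(OC)cc(-c2cccc(NC(=O)CCc3cccc4c3B(O)OC4)c2)c1`) differs from compound 2 as follows: 3,5-dimethoxyphenyl in place of phenyl on an aromatic carbon. Among the compounds with values here, the one measured step bearing on this change is a 1.8-fold lower number from compound 1 to compound 2 (0.25 log units; within the scatter), and it stays within the scatter. Within the data shown here, no measured compound carries methoxy groups, so the direction of any shift remains open. No step beyond the scatter is therefore expected in this assay. The estimate amounts to an expected 1.1-fold lower number from compound 2 to compound 3 (0.05 log units; within the scatter). For compound 3 the expected value is 800 nM, with an estimated range of 300 nM to 2100 nM.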

Compound 3, half-maximal inhibitory concentration: 53 nM
The estimate for compound 3 lay 15-fold (1.18 log units) above the measured number, outside the stated range (below it).
By their numbers in this assay, from the lowest: compound 3; then compounds 2 and 1 (each within the scatter of the next).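

In this assay this position proves sensitive to the aryl group it carries: 3,5-dimethoxyphenyl in place of phenyl brings a 17-fold lower number from compound 2 to compound 3 (1.23 log units; beyond the scatter), whereas phenyl in place of isopropyl had stayed within the scatter. Against the isopropyl compound the same group brings a 30-fold lower number from compound 1 to compound 3 (1.48 log units; beyond the scatter), so compound 3 stands clear of both earlier compounds, and a plain phenyl ring does not by itself account for the low number. Nothing at hand explains this step.

The compounds shown leave open whether the step needs both methoxy groups or whether one would do, and whether hydroxyl or an amine in their place would hold the number. Also open, on these data alone, is whether the low number of compound 3 carries over to other cell lines.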